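Swapping a cyclopropyl for a methyl on an isoindolinone carbon

The compounds below may be only part of what the source reports. "The series", "measured", "known", "first", "only" and "open" are said of these compounds alone.

Measured compounds:
Compound 1 `CC(=O)N[C@@H]1CCCc2c1cncc2N1C(=O)c2ccc(Cl)cc2[C@@H]1C1CC1` gives 354 nM in an assay on cells for inhibition of cytochrome P450 11B2, mitochondrial (Homo sapiens), read by HTRF; on this read-out higher numbers stand for weaker inhibition and lower numbers for stronger inhibition.
Compound 2 `O=C1c2ccc(Cl)cc2CN1c1cccnc1` gives 179 nM in this assay.
Compound 3 `CC(=O)N1CCC(Oc2cncc(N3C(=O)c4ccc(Cl)cc4C3(C)C)c2)CC1` gives 4 nM in this assay.

Compound 1 has the highest number of the three; compound 2 sits within the scatter of it, while compound 3 lies far lower, beyond the scatter. Compound 4 `CC(=O)N[C@@H]1CCCc2c1cncc2N1C(=O)c2ccc(Cl)cc2[C@@H]1C` differs from compound 1 in one spot: methyl in place of cyclopropyl on a saturated ring carbon. For the measured compounds named here, no measured pair isolates this change, so the expected step rests only on the size of the group swapped. A small shift is expected, with no step beyond the scatter in this assay. Compound 4 is therefore estimated at 300 nM (range 100 nM to 900 nM), a step of a 1.2-fold lower number from compound 1 to compound 4 (0.07 log units; within the scatter).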

Compound 4, half-maximal inhibitory concentration: 4 nM
For compound 4 the middle estimate is 75-fold (1.88 log units) above the measured one; measured number outside the range, below it.
By their numbers in this assay, from the lowest: compounds 3 and 4 (each within the scatter of the next); then compounds 2 and 1 (each within the scatter of the next).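

In this assay, methyl in place of cyclopropyl on this saturated ring carbon gives an 89-fold lower number from compound 1 to compound 4 (1.95 log units; beyond the scatter), so the group at this one position strongly affects the read-out. Neither group carries a hydrogen-bond donor, hydrogen-bond acceptor or net charge, so a swap between two small carbon groups is enough to produce a large step. Nothing available explains why the step is so large.

The compounds shown leave open how an ethyl or a hydroxymethyl group on this carbon would compare. They also do not show whether a plain hydrogen there would fall nearer compound 1 or compound 4.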